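From pinacol boronate to free acid: a small change

This account rests on a few compounds, and the source may have more. Where it says the series, first, only, none or still open, it means among the compounds named here.

Compound 1 `CC1(C)OB(c2ccc(O)c(NC(=O)COc3ccc(C4CCCCC4)cc3)c2)OC1(C)C` gives 13400 nM in a functional assay on HeLa cells (Homo sapiens) for inhibition, read by MTT assay, with a stated time of 48 h (a higher number here means a weaker inhibitor of growth, a lower number a stronger inhibitor of growth), the higher of the two numbers recorded, its nearest neighbour being compound 2 `CC(C)(C)c1ccc(OCC(=O)Nc2cc(B3OC(C)(C)C(C)(C)O3)ccc2O)cc1`, which gives 12100 nM in this assay. Compound 3 `O=C(COc1ccc(C2CCCCC2)cc1)Nc1cc(B(O)O)ccc1O` differs from compound 1 in one place: a group of 3 heavy atoms (1 boron, 2 oxygen; no ring) in place of a group of 9 heavy atoms (6 carbon, 1 boron, 2 oxygen; one five-membered non-aromatic ring with 3 hetero atoms), on an aromatic carbon. For the measured compounds named here, the only recorded step, a 1.1-fold lower number from compound 1 to compound 2 (0.04 log units; within the scatter), concerns a different part of the structure and does not bear on this change, so no step beyond the scatter is expected, a 1.1-fold lower number from compound 1 to compound 3 (0.05 log units; within the scatter). Compound 3 is therefore estimated at 12000 nM, with a range from 4000 nM to 40000 nM.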

Compound 3, concentration for 50% growth inhibition: 29200 nM
The estimate for compound 3 lay 2.4-fold (0.39 log units) below the measured number; the range from low to high includes it.
By their numbers in this assay, from the lowest: compounds 2 and 1 (each within the scatter of the next); then compound 3.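

In this assay, the change on the aromatic carbon para to a hydroxy group gives a 2.2-fold higher number from compound 1 to compound 3 (0.34 log units; beyond the scatter), so unlike the earlier swap of cyclohexyl for tert-butyl, this position produces a step beyond the scatter. The group of 9 heavy atoms with its five-membered ring goes with the lower number, although the step is modest. Nothing measured here explains the step.

As far as these compounds go, whether the same step appears with tert-butyl in place of cyclohexyl remains open. So does what a carboxylic acid or an amine would give on that aromatic carbon.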